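Chain branching beside the tetrazole in a hydroxyacetophenone series

A few compounds are considered here, and "the series" means these few. Any claim that something is new, unique, unknown or untested is made for them only; others in the source may bear on it.

Compound 2 `CCCc1c(COc2ccc(C(=O)C(C)Cc3nnn[nH]3)cc2)ccc(C(C)=O)c1O` gives 9.2 mg/kg in an in vivo functional assay on the whole organism (Rattus norvegicus) with cysteinyl leukotriene receptor (Homo sapiens) as the target (a lower number here means that less compound is needed, a higher number that more compound is needed for the effect), and stands second highest of the three numbers. Compound 1 `CCCc1c(COc2ccc(C(=O)Cc3nnn[nH]3)cc2)ccc(C(C)=O)c1O` gives 24.1 mg/kg; compound 3 `CCc1c(COc2ccc(C(=O)CC(C)(C)CC(=O)O)cc2)ccc(C(C)=O)c1O` gives 1.4 mg/kg, the lowest number shown, though no single step connects it to compound 2. Compound 4 `CCCc1c(COc2ccc(C(=O)CC(C)(C)Cc3nnn[nH]3)cc2)ccc(C(C)=O)c1O` carries 2-((1H-tetrazol-5-yl)methyl)-2-methylpropyl in place of 1-((1H-tetrazol-5-yl)methyl)ethyl on a carbonyl carbon. For the measured compounds named here, the one measured step that bears on this is a 2.6-fold lower number from compound 1 to compound 2 (0.42 log units; beyond the scatter), where added branching on the same chain lowered the number. A further gain of similar size is therefore expected for compound 4, without a measured step reaching as far as compound 3. The estimate for compound 4 is 4.5 mg/kg (range 1.5 mg/kg to 14 mg/kg), a change of a 2.0-fold lower number from compound 2 to compound 4 (0.31 log units; beyond the scatter) that is expected from compound 2.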

Compound 4, dose for half-maximal effect: 1.3 mg/kg
Beside the measured number, compound 4's estimate is 3.5-fold (0.54 log units) above it; the whole stated range lies above it.
By their numbers in this assay, from the lowest: compounds 4 and 3 (each within the scatter of the next); then compound 2; then compound 1.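

The 2-((1H-tetrazol-5-yl)methyl)-2-methylpropyl group on the carbonyl carbon gives, in this assay, a further fall (a 7.1-fold lower number from compound 2 to compound 4 (0.85 log units; beyond the scatter)), so this position has more room for change than compound 2 suggested. Against the starting chain, the change amounts to a large step (a 19-fold lower number from compound 1 to compound 4 (1.27 log units; beyond the scatter)), and the numbers fall in the order compound 1, compound 2, compound 4, with none of these three against that order. No evidence on why the number falls is available.

For the compounds shown here, because this group differs from the one in compound 2 in both chain length and branching, the contributions of the two remain unseparated. As far as these compounds go, an unbranched longer chain carrying the tetrazole, or a cyclopropyl ring in place of the two methyl groups, remains open.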